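From Benzyl to 4-Propylphenyl on a Shared Core

The source may hold more compounds than are shown below. What is called first, only, known or untested is meant among the compounds shown, and "the series" means these compounds.

Three compounds have been measured in a functional assay on MGC-803 cells (Homo sapiens) for inhibition, read by sulforhodamine B assay; a lower number here means a stronger inhibitor, a higher number a weaker inhibitor:

compound 1, `O=C1C=C(NCc2ccccc2)C(=O)c2c1nc1n2[C@H]2OC[C@@H](O)[C@H]2OC1`, gives 2670 nM
compound 2, `CCOc1ccccc1NC1=CC(=O)c2c(nc3n2[C@H]2OC[C@@H](O)[C@H]2OC3)C1=O`, gives 2830 nM
compound 3, `O=C1C(Nc2ccccc2F)=CC(=O)c2c1nc1n2[C@H]2OC[C@@H](O)[C@H]2OC1`, gives 2000 nM

Compound 1 stands second highest of the three numbers. Its nearest neighbour is compound 2, whose value lies within the scatter of that of compound 1; the furthest is compound 3, also within the scatter. Among the measured compounds shown here, the only step between compounds differing in one place is a 1.4-fold lower number from compound 2 to compound 3 (0.15 log units; within the scatter), so nothing measured so far moves beyond the scatter.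

Compound 4, `CCCc1ccc(NC2=CC(=O)c3nc4n(c3C2=O)[C@H]2OC[C@@H](O)[C@H]2OC4)cc1`, differs from compound 1 as follows: 4-propylphenyl in place of benzyl on an amine nitrogen

For the measured compounds named here, no measured step exchanges benzyl for an aryl group on that amine nitrogen. Compounds 2 and 3 do carry aryl groups on the amine nitrogen, and their values sit close to that of compound 1, which suggests that the nature of the group on this nitrogen has so far made little difference. The step from compound 1 to compound 4 is therefore expected to stay within the scatter, a 1.2-fold lower number from compound 1 to compound 4 (0.06 log units; within the scatter). Compound 4 is estimated at 2300 nM, with a range from 900 nM to 6000 nM in this assay.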

Compound 4, half-maximal inhibitory concentration: 1560 nM
For compound 4 the middle estimate is 1.5-fold (0.17 log units) above the measured one, within the range that was stated.
By their numbers in this assay, from the lowest: compounds 4, 3, 1 and 2 (each within the scatter of the next).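

In this assay, replacing benzyl with 4-propylphenyl on the amine nitrogen gives a 1.7-fold lower number from compound 1 to compound 4 (0.23 log units; within the scatter), so this exchange at the position leaves the value within the scatter. The earlier step concerned only a substituent on an aromatic ring already present, whereas this one replaces the whole group on the nitrogen with a larger one made only of carbon, and even that does not carry the value beyond the scatter. No evidence is available that would explain this outcome or tie it to any property of either group.

The compounds shown leave open whether the tolerance holds only for groups like these, which have no hydrogen-bond donors or acceptors, or also extends to a 4-propylphenyl analogue with a longer chain, or with an amine or a carboxylic acid at the end of that chain. They also leave open whether a small alkyl group such as methyl on the amine nitrogen, with no aromatic ring at all, would give a value within the same scatter.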